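From Compound 2 to Compound 4 in Ovarian Cell Inhibition

A few compounds are considered here, and "the series" means these few. Any claim that something is new, unique, unknown or untested is made for them only; others in the source may bear on it.

Three amides share a benzylamide bearing a sulfonyl group and differ in the acyl part. Compound 1 `O=C(NCc1ccc(S(=O)(=O)c2ccccc2)cc1)c1ccc2ccncc2c1` reaches only a limit in a functional assay on A2780 cells (Homo sapiens) for inhibition, read by sulforhodamine B assay, with a stated time of 72 h (on this read-out lower numbers stand for stronger inhibition and higher numbers for weaker inhibition), giving > 10000 nM. Compound 3 `O=C(NCc1ccc(S(=O)(=O)N2CCCCC2)cc1)c1cc2cccnc2s1` likewise gives only the limit > 10000 nM in this assay. Within the data shown here, compound 2 `O=C(NCc1ccc(S(=O)(=O)c2ccccc2)cc1)c1cc2ccncc2s1` gives 14 nM in this assay, the only numerical value of the three; the other two sit at the limit of > 10000 nM in this assay, at which 2 of the 3 values shown sit.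

Compound 4 `O=C(NCc1ccc(S(=O)(=O)c2ccccc2)cc1)c1c[nH]c2ccncc12` differs from compound 2 in one place: a group of 9 heavy atoms (7 carbon, 2 nitrogen; one five-membered aromatic ring with 1 hetero atom, one six-membered aromatic ring with 1 hetero atom) in place of a group of 9 heavy atoms (7 carbon, 1 nitrogen, 1 sulfur; one five-membered aromatic ring with 1 hetero atom, one six-membered aromatic ring with 1 hetero atom), on a carbonyl carbon. The entering group has 1 hydrogen-bond donor where the leaving group has 0 hydrogen-bond donors. Among the measured compounds shown here, no measured pair of compounds shows the effect of such a change, so the size of the step in this assay is open. Compound 1 and compound 3 show only limits, and a weakening beyond the usual scatter is therefore expected rather than a gain. Compound 4 is expected to give 150 nM in this assay, within a range from 20 nM to 3000 nM. The expected step of an 11-fold higher number from compound 2 to compound 4 (1.03 log units; beyond the scatter) is a loss, with a fair chance that only a limit is returned.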

Compound 4, half-maximal inhibitory concentration: 2100 nM
Compound 4: middle estimate off by 14-fold (1.15 log units), on the low side; measured number inside the range.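

In this assay, the exchange on the carbonyl carbon gives a 150-fold higher number from compound 2 to compound 4 (2.18 log units; beyond the scatter), so this position responds strongly even though both groups hold 9 heavy atoms and the same kinds of aromatic ring. The entering group has 1 hydrogen-bond donor and 1 hydrogen-bond acceptor where the leaving group has 0 and 2, but this single pair cannot separate those counts from the exchange of sulfur for nitrogen. Nothing measured here gives a cause for the loss.

On these data alone, it remains open whether a methyl group in place of the hydrogen on the nitrogen of the five-membered ring would change the value of compound 4 in this assay. As far as these compounds go, it also remains open how a group with oxygen in place of the sulfur of compound 2 would compare.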